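Adding a Second Fluorine Where Plasma Binding Is Already Tight

A few compounds are considered here, and "the series" means these few. Any claim that something is new, unique, unknown or untested is made for them only; others in the source may bear on it.

Compound 1, with the structure `COc1c(F)cccc1C1CCN(c2ccn3c(CC(F)(F)F)nnc3c2C#N)CC1`, and compound 2, with the structure `COc1cccc(F)c1C1CCN(c2ccn3c(CC4CC4)nnc3c2Cl)CC1`, share a core but differ in several places at once, so the gap between their numbers cannot be tied to any single change. In an ADME assay on a cell-free system (plasma, Rattus norvegicus) for protein binding (on this read-out lower numbers stand for a smaller free fraction and higher numbers for a larger free fraction), compound 1 gives 0.04. In this assay compound 2 gives < 0.01, which is a limit of the assay rather than a number, the limit described by the limit of < 0.01 in this assay, at which 1 of the 2 values shown sits. Compound 3, with the structure `COc1c(F)ccc(F)c1C1CCN(c2ccn3c(CC4CC4)nnc3c2Cl)CC1`, is compound 2 with one change: fluoro in place of hydrogen on an aromatic carbon. Since compound 2 already stands at a limit, in this assay the step is expected to be a step that the limit leaves unreadable from compound 2 to compound 3, small or none beyond the usual scatter. Compound 3 is therefore expected to give 0.006, within a range from 0.002 to 0.015, most likely reported again as a limit.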

Compound 3, unbound fraction: < 0.01
Compound 3 ended at the assay's limit; the forecaster's own chance of this, stated with the estimate: 75%; the middle value does not contradict the limit.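

Compound 2 and compound 3 both stand at a limit rather than at a number, so no step can be read between them: the limit of < 0.01 in this assay, at which 2 of the 3 values shown sit. The compounds shown leave open whether fluoro in place of hydrogen on an aromatic carbon changes the result at all in this assay.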